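Aryl exchange from compound 2 to compound 3

This account rests on a few compounds, and the source may have more. Where it says the series, first, only, none or still open, it means among the compounds named here.

For the measured compounds named here, in a functional assay on KB cells (Homo sapiens) for antiproliferative activity, read by sulforhodamine B assay, with a stated time of 3 days (a lower number here means that less compound is needed, a higher number that more compound is needed for the effect), compound 2 (`CCC1=C(O)c2c(oc(-c3ccc(C)cc3C)cc2=O)C(CC)(CC)C1=O`) gives 41.2 uM, the only actual number so far. Compound 1 (`CCC1=C(O)c2c(oc(-c3cccc(F)c3)cc2=O)C(CC)(CC)C1=O`), with 3-fluorophenyl, reads > 56.2 uM, which is a limit of the assay. Going by the values given here, the single measured step is an at least 1.3-fold lower number from compound 1 to compound 2 (0.13 log units; that floor lies within the scatter), and its floor lies within the scatter. Compound 3 (`CCC1=C(O)c2c(oc(-c3ccc(C)c(F)c3)cc2=O)C(CC)(CC)C1=O`) carries 3-fluoro-4-methylphenyl in place of 2,4-dimethylphenyl (3-fluoro-4-methylphenyl in place of 2,4-dimethylphenyl on an aromatic carbon). Among the compounds with values here, with only that step as a guide, no shift beyond the scatter is expected in this assay. The expected step is a 1.1-fold higher number from compound 2 to compound 3 (0.04 log units; within the scatter). For compound 3 the estimate is 45 uM, with an expected range of 22 uM to 70 uM.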

Compound 3, concentration for half-maximal effect: 28.1 uM
Beside the measured number, compound 3's estimate is 1.6-fold (0.20 log units) above it; low and high end bracket the measured number.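

With the aryl exchange at this position, this assay shows a 1.5-fold lower number from compound 2 to compound 3 (0.17 log units; within the scatter), so 3-fluoro-4-methylphenyl and 2,4-dimethylphenyl are not separated here. Methyl in place of hydrogen on an aromatic carbon gives an at least 2.0-fold lower number from compound 1 to compound 3 (0.30 log units; that floor lies within the scatter), which is a floor and does not establish a gain. That floor rests on the reading of compound 1, which is a limit: the limit of > 56.2 uM in this assay, at which 1 of the 3 values shown sits.

Going by these compounds, whether any change on this aryl group moves the number beyond the scatter stays open. Also open, on these data alone, is how an amine or a carboxylic acid on this aryl group would read.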